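Carboxymethyl for Chloro on a Biaryl Amide: Cytotoxicity Outlook

This account rests on a few compounds, and the source may have more. Where it says the series, first, only, none or still open, it means among the compounds named here.

Three compounds share one core and differ only in the group on the outer aromatic ring. Compound 1 `CCOC(=O)CCCCCOc1cccc(CN(C(=O)c2ccc(-c3cccc(N(C)C)c3)cc2)C(C)C)c1` carries a 3-(dimethylamino)phenyl there; in an ADME assay on HepG2 cells (Homo sapiens) for cytotoxicity, read by CellTiter-Glo and resazurin assay, with a stated time of 72 h (a lower number here means that less compound is needed, a higher number that more compound is needed for the effect), compound 1 gives > 26000 nM, which is a limit of the assay and not a number. Compound 2 `CCOC(=O)CCCCCOc1cccc(CN(C(=O)c2ccc(-c3cccnc3)cc2)C(C)C)c1` carries a pyridin-3-yl, and in this assay compound 2 gives > 26000 nM, again only a limit. Compound 3 `CCOC(=O)CCCCCOc1cccc(CN(C(=O)c2ccc(-c3cccc(Cl)c3)cc2)C(C)C)c1` carries a 3-chlorophenyl, and in this assay compound 3 gives > 18400 nM, also a limit. With all three values being limits, the steps between them cannot be sized: a step that the two limits leave unreadable from compound 1 to compound 2, a step that the two limits leave unreadable from compound 1 to compound 3 and a step that the two limits leave unreadable from compound 2 to compound 3. Compound 3 thus stands at the limit of > 18400 nM in this assay, at which 1 of the 3 values shown sits, while the other two stand at the limit of > 26000 nM in this assay, at which 2 of the 3 values shown sit; none of the three shows a measurable effect within the tested range.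

Compound 4 `CCOC(=O)CCCCCOc1cccc(CN(C(=O)c2ccc(-c3cccc(CC(=O)O)c3)cc2)C(C)C)c1` is not yet measured. It differs from compound 3 in one place: carboxymethyl in place of chloro on an aromatic carbon. The measured steps that bear on this change are the three between compound 1, compound 2 and compound 3, and each of them is unreadable, so they give no direction. The expected step in this assay is therefore none beyond the scatter: a step that the limit leaves unreadable from compound 3 to compound 4. Compound 4 is expected to give 30000 nM in this assay, with a range from 15000 nM to 80000 nM, most likely reported as a limit once more.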

Compound 4, half-maximal effective concentration: > 26000 nM
Compound 4 was reported as a limit (the forecaster's own chance of this, stated with the estimate: 85%); the middle value does not contradict the limit.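

In this assay compound 4 gives > 26000 nM, a limit of the assay and not a number. The steps from compound 1, compound 2 and compound 3 to compound 4 cannot be read: all four values are limits. Left open is the concentration at which any of these compounds reaches its half-maximal effect, and whether swapping the group on the outer ring changes it at all.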